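Furan Attachment Point Swap Tested on Adenosine Receptor Binding

The source may hold more compounds than are shown below. What is called first, only, known or untested is meant among the compounds shown, and "the series" means these compounds.

Measured compounds:
Compound 1, `CC1=C(C(=O)OCC(C)C)C(c2ccco2)NC(=O)N1C`: 13%
Compound 2, `CC1=C(C(=O)OCC(C)C)C(c2ccoc2)NC(=O)N1C`: 4%
Compound 3, `CCSC(=O)C1=C(C)NC(=O)NC1c1ccco1`: 6%

All three were tested in an assay on membranes from CHO cells for displacement of a labelled ligand from adenosine receptor A1 (Homo sapiens), read by scintillation counting, with a stated time of 60 min, tested at 1 uM; on this read-out lower numbers stand for less inhibition and higher numbers for more inhibition at the one concentration tested (going by the name of the read-out). In this assay compound 1 gives 13%, while compound 2 gives 4%. The two differ only by furan-3-yl in place of furan-2-yl on a saturated ring carbon, and that change produced a number 9 percentage points lower from compound 1 to compound 2 (within the scatter), so the two numbers cannot be told apart. Compound 3 gives 6%, which lies within the scatter of both compound 1 and compound 2. How the core of compound 3 differs from the core of compound 1 is not broken down here.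

Compound 4, `CCSC(=O)C1=C(C)NC(=O)NC1c1ccoc1`, has not yet been measured. It differs from compound 3 by furan-3-yl in place of furan-2-yl on a saturated ring carbon. Among the compounds with values here, this is the same kind of change as the one from compound 1 to compound 2, although the neighbouring group differs: an (ethylsulfanyl)carbonyl group in place of an isobutoxycarbonyl group. Because a number 9 percentage points lower from compound 1 to compound 2 (within the scatter) stayed within the scatter, a similarly small step is expected, namely a number 3 percentage points lower from compound 3 to compound 4 (within the scatter). For compound 4 the expected value in this assay is 3%, with a range from -6% to 12%.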

Compound 4, a percentage reported as inhibition, at one concentration (the size of the read-out at that concentration, not a potency): 3%
The estimate for compound 4 equals the measured number at the digits printed; the measured number falls inside the stated range.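

In this assay, the swap on the second core gave a number 3 percentage points lower from compound 3 to compound 4 (within the scatter), and set beside the earlier step it gives no sign that the core changes the outcome: the same change on two cores in this assay, a number 9 percentage points lower (within the scatter) from compound 1 to compound 2 and a number 3 percentage points lower (within the scatter) from compound 3 to compound 4, 6 percentage points apart, within the scatter of two such steps. Within these four compounds, then, furan-3-yl can replace furan-2-yl on a saturated ring carbon on either core without a step that stands out from the usual scatter. This does not prove that the swap acts identically on both cores, or on any other core, since neither step can be told from no change at all, and a reading at one concentration is not a potency.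

The compounds shown carry only the two furan groups at this ring carbon, so it remains open how a phenyl or thiophene ring would read there. As far as these compounds go, it also remains open whether an amine or a carboxylic acid in place of the isobutoxycarbonyl or (ethylsulfanyl)carbonyl group would give a step large enough to stand clear of the scatter.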